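Lengthening the side chain from compound 2 to compound 3

The source may hold more compounds than are shown below. What is called first, only, known or untested is meant among the compounds shown, and "the series" means these compounds.

Compound 1 `COc1ccc2c(c1)CCc1c(-c3ccccc3)c3n(c1-2)[B-](F)(F)[N+]1=C(c2ccc(OCC(=O)O)cc2)C(I)=C(c2ccccc2)C1=N3`: > 50000 nM
Compound 2 `COc1ccc2c(c1)CCc1c(-c3ccccc3)c3n(c1-2)[B-](F)(F)[N+]1=C(c2ccc(OCC(=O)N[C@@H](CC(=O)O)C(=O)O)cc2)C(I)=C(c2ccccc2)C1=N3`: > 250000 nM

Both entries come from an ADME assay on B16-F10 cells (Mus musculus) for cytotoxicity, read by CCK-8 assay, with a stated time of 16 h (on this read-out higher numbers stand for weaker inhibition and lower numbers for stronger inhibition), and neither is a number: each is a limit of the assay. In this assay compound 2 sits at the limit of > 250000 nM, the higher of the two limits shown.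

Compound 3 `COc1ccc2c(c1)CCc1c(-c3ccccc3)c3n(c1-2)[B-](F)(F)[N+]1=C(c2ccc(OCC(=O)N[C@@H](CCC(=O)O)C(=O)O)cc2)C(I)=C(c2ccccc2)C1=N3` carries carboxymethyl in place of carboxy on a saturated chain carbon, two bonds along the chain from an amide-type nitrogen and a carbonyl carbon.

Among the measured compounds shown here, the one measured step that bears on this is a step that the two limits leave unreadable from compound 1 to compound 2, where (1,2-dicarboxyethyl)amino takes the place of hydroxy on a carbonyl carbon. It offers no size to carry over, so no change beyond the usual scatter is expected, and a limit is the likeliest report. The expected change is a number no higher from compound 2 to compound 3 (the limit leaves the size open). For compound 3 the estimate is 250000 nM, with an expected range from 100000 nM to 500000 nM.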

Compound 3, half-maximal inhibitory concentration in the B16-F10 assay: > 250000 nM
Compound 3 ended at the assay's limit; the forecaster's own chance of this, stated with the estimate: 80%; the middle value lies on the limit itself.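

In the B16-F10 assay, compound 1 gives > 50000 nM, which is a limit of the assay. In the B16-F10 assay, compound 2 gives > 250000 nM, which is also a limit of the assay. In the B16-F10 assay, compound 3 gives > 250000 nM, which is also a limit of the assay. Among the compounds shown here, no step among compound 1, compound 2 and compound 3 can be read in this assay, and these limits leave open what number any of them would give. In a physicochemical assay for solubility, in phosphate buffer (a lower number here means a less soluble compound, a higher number a more soluble compound), compound 2 gives 115000 nM and compound 3 gives 110000 nM. In the physicochemical assay, the measured step is a 1.0-fold lower number from compound 2 to compound 3 (0.02 log units; within the scatter).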